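Fluoro for bromo: one atom changed in compound 3

The source may report more compounds than this note shows. Statements on the series, on what has been measured and on what is new or still open speak of the compounds shown alone.

Compound 1 `O=C(/C=C/c1ccc(OCc2cn(Cc3ccccc3F)nn2)cc1)c1ccc(Br)cc1`: 38%
Compound 2 `O=C(/C=C/c1ccc(OCc2cn(Cc3ccccc3Br)nn2)cc1)c1ccc([N+](=O)[O-])cc1`: 43%

In a functional assay on MCF7 cells (Homo sapiens) for inhibition, read by MTT assay, with a stated time of 48 h, tested at 10 uM (on this read-out lower numbers stand for less inhibition of growth and higher numbers for more inhibition of growth at the one concentration tested), compound 2 gives 43% and compound 1 gives 38%; the two numbers lie within the scatter of each other, so compound 2 stands level with compound 1. Compound 3 `O=C(/C=C/c1ccc(OCc2cn(Cc3ccccc3F)nn2)cc1)c1ccc([N+](=O)[O-])cc1` differs from compound 2 by fluoro in place of bromo on an aromatic carbon. Going by the values given here, no measured pair shows this swap on its own. The step from compound 2 to compound 3 is expected to be a number 3 percentage points lower from compound 2 to compound 3 (within the scatter), nothing beyond the scatter, because compound 1 with the same fluoro gives 38%. Compound 3 is estimated at 40%, between 28% and 52%.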

Compound 3, percent growth inhibition at one concentration: 33%
The estimate for compound 3 lay 7 percentage points above the measured number; measured number inside the range.
By their numbers in this assay, from the lowest: compounds 3, 1 and 2 (each within the scatter of the next).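

Two single-place comparisons can now be read in this assay: fluoro in place of bromo gives a number 10 percentage points lower from compound 2 to compound 3 (within the scatter), and nitro in place of bromo gives a number 5 percentage points lower from compound 1 to compound 3 (within the scatter). Neither swap moves the number beyond the scatter, so at this one concentration bromo and fluoro at the place ortho to a large group cannot be told apart, nor can bromo and nitro on the other aromatic ring. No measurement here offers an explanation for these steps. Open, from the compounds shown here alone, is whether an amine at the first place, or a carboxylic acid in place of nitro, would give a step beyond the scatter.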